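Swapping a benzimidazole for a cyclopentyl urea on the shared core

This account rests on a few compounds, and the source may have more. Where it says the series, first, only, none or still open, it means among the compounds named here.

Measured compounds:
- compound 1, `Cc1nc(NC(=O)NC2CCCCC2)c(C)c(C(OC(C)(C)C)C(=O)O)c1-c1ccc2c(c1)CCCO2`: 17000 nM
- compound 2, `Cc1ccc(-c2c(C)nc(Nc3nc4ccccc4n3C)c(C)c2C(OC(C)(C)C)C(=O)O)cc1C`: 14000 nM

In an ADME assay on MT4 cells (Homo sapiens) for cytotoxicity, read by MTT assay (a higher number here means that more compound is tolerated, a lower number that less compound is tolerated), compound 1 gives 17000 nM and compound 2 gives 14000 nM. For the measured compounds named here, the two numbers lie within the scatter of each other, so compound 2 cannot be told apart from compound 1 in this assay; neither is a standout on the numbers so far.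

Compound 3, `Cc1ccc(-c2c(C)nc(NC(=O)NC3CCCC3)c(C)c2C(OC(C)(C)C)C(=O)O)cc1C`, is not yet measured. It differs from compound 2 in one place: cyclopentylcarbamoyl in place of 1-methyl-1H-benzimidazol-2-yl on a nitrogen on an aromatic ring. Compound 1 carries a closely related urea on its own core, and its value in this assay sits close to that of compound 2. Going by the values given here, no measured pair shows this exact swap, so the step from compound 2 to compound 3 is expected to be small, with no direction beyond the scatter, giving a 1.1-fold higher number from compound 2 to compound 3 (0.06 log units; within the scatter). Compound 3 is therefore expected to give about 16000 nM in this assay, within a range from 8000 nM to 32000 nM.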

Compound 3, half-maximal cytotoxic concentration: 8000 nM
Beside the measured number, compound 3's estimate is 2.0-fold (0.30 log units) above it; the measured number falls inside the stated range.
By their numbers in this assay, from the lowest: compounds 3, 2 and 1 (each within the scatter of the next, the first and the last beyond it).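

In this assay, replacing the 1-methyl-1H-benzimidazol-2-yl group on the nitrogen with the cyclopentylcarbamoyl group gives a 1.8-fold lower number from compound 2 to compound 3 (0.24 log units; within the scatter). For the compounds shown here, this is the first direct reading of this position, and it shows that two quite different groups, one with aromatic rings and no hydrogen-bond donor and the other with a non-aromatic carbon ring and a hydrogen-bond donor, cannot be told apart in this read-out. No available evidence bears on why the step has this size.

From the compounds shown here alone, it remains open whether a free amine, an acetyl group or a longer chain on this nitrogen would move the number beyond the scatter. Cytotoxicity is also the only read-out shown, so the effect of this swap on anything else remains unknown.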